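This account rests on a few compounds, and the source may have more. Where it says the series, first, only, none or still open, it means among the compounds named here.

Compound 1 `CCN(CC#CC#CC(C)(C)OC)Cc1cccc(OC[Si](C)(C)c2ccccc2C)c1` gives 70 nM in a functional assay on liver (Sus scrofa) for inhibition of squalene monooxygenase (Homo sapiens), using microsomes; a lower number here means a stronger inhibitor, a higher number a weaker inhibitor. Compound 2 `CCN(C/C=C/C#CC(C)(C)C)Cc1cccc(OC[Si](C)(C)c2ccc(Br)cc2)c1` gives 210 nM in this assay. Compound 3 `CCN(C/C=C/C#CC(C)(C)C)Cc1cccc(OC[Si](C)(C)c2ccccc2C(F)(F)F)c1` gives 70 nM in this assay.

Compound 3 stands level with compound 1 at the digits shown, and the two share the lowest number of the three, with compound 2 the furthest away. Within the data shown here, the only measured change on the silicon is a 3.0-fold lower number from compound 2 to compound 3 (0.48 log units; beyond the scatter). Compound 4 `C=Cc1ccc([Si](C)(C)COc2cccc(CN(CC)C/C=C/C#CC(C)(C)C)c2)cc1` differs from compound 3 by 4-vinylphenyl in place of 2-(trifluoromethyl)phenyl on a silicon. This brings back a 4-substituted ring of the kind carried by compound 2, whose value 210 nM lies above that of compound 3. A single step is thin ground, so only a modest rise in this assay is expected. Compound 4 is therefore estimated at 150 nM, within 60 nM to 400 nM, which would mean a 2.1-fold higher number from compound 3 to compound 4 (0.33 log units; beyond the scatter).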

Compound 4, half-maximal inhibitory concentration: 70 nM
For compound 4 the middle estimate is 2.1-fold (0.33 log units) above the measured one; the measured number falls inside the stated range.
By their numbers in this assay, from the lowest: compounds 1, 3 and 4 (each within the scatter of the next); then compound 2.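

In this assay there is no change at the digits printed from compound 3 to compound 4 (within the scatter), so 4-vinylphenyl on the silicon serves as well as 2-(trifluoromethyl)phenyl. A ring named with a 4-substituent therefore need not raise the number, since there is also a 3.0-fold lower number from compound 2 to compound 4 (0.48 log units; beyond the scatter) with vinyl in place of bromo on that aromatic carbon. Nothing given here explains this gap between vinyl and bromo. As far as these compounds go, how an amine or a carboxylic acid would fare in place of vinyl remains open. So does whether a longer chain there would keep the number of compound 4.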